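Swapping the anilino substituent on a thiazolyl chalcone series

The compounds below may be only part of what the source reports. "The series", "measured", "known", "first", "only" and "open" are said of these compounds alone.

In a functional assay on BGC-823 cells (Homo sapiens) for cytotoxicity, read by MTT assay (on this read-out higher numbers stand for weaker inhibition and lower numbers for stronger inhibition), compound 1 `COc1cc(/C=C/C(=O)c2sc(Nc3ccccc3C)nc2C)cc(OC)c1OC` gives 5400 nM. Among the compounds with values here, only one other compound gives a number here: compound 2 `COc1cccc(/C=C/C(=O)c2sc(Nc3ccc(Cl)c(Cl)c3)nc2C)c1` gives 8350 nM in this assay, and the two values sit within the usual scatter of each other, so neither can be called stronger than the other. Compound 3 `Cc1cccc(Nc2nc(C)c(C(=O)/C=C/c3ccc(Cl)cc3)s2)c1` reaches only the limit of the assay, > 25000 nM, and no number is known for it; this is the limit of > 25000 nM in this assay, at which 1 of the 3 values shown sits.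

The next compound, compound 4 `COc1cc(/C=C/C(=O)c2sc(Nc3ccc(Cl)c(Cl)c3)nc2C)cc(OC)c1OC`, is compound 1 with one change: 3,4-dichlorophenyl in place of 2-methylphenyl on a nitrogen on an aromatic ring. The same 3,4-dichlorophenyl group already appears in compound 2, which shares nothing else with compound 1 apart from the core, and the values of compound 1 and compound 2 lie within the scatter. Within the data shown here, no measured pair in this set shows exactly this exchange, so no step can be read off for it.

The estimated step from compound 1 to compound 4 is therefore expected to be small, a 1.1-fold higher number from compound 1 to compound 4 (0.05 log units; within the scatter), with no direction beyond the scatter. Compound 4 is expected to give about 6000 nM in this assay, somewhere between 2500 nM and 15000 nM.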

Compound 4, half-maximal inhibitory concentration: > 25000 nM
Compound 4 gave a limit, no number (the forecaster's own chance of this, stated with the estimate: 10%); at least 4.1-fold (0.61 log units) between middle value and limit.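

Within the data shown here, the exchange on a nitrogen on an aromatic ring gives the first direct reading of this position in the set: 3,4-dichlorophenyl in place of 2-methylphenyl gives an at least 4.6-fold higher number from compound 1 to compound 4 (0.66 log units; beyond the scatter) in this assay. Among these compounds, with the rest of compound 1 held constant, the group at this position is therefore not interchangeable, a point the earlier compounds could not show, as no two of them differ in only one place. Compound 4 stands at a limit and not at a number, and it is the second compound shown to do so: the limit of > 25000 nM in this assay, at which 2 of the 4 values shown sit.

How far compound 4 lies past that limit cannot be told, and the compounds shown do not separate the arrival of the two chlorine atoms from the departure of the methyl group. As far as these compounds go, whether a single chlorine, a methoxy group or an amine on the phenyl ring, or a short alkyl chain on the nitrogen in place of the ring, would keep the value that compound 1 gives remains open.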